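This account rests on a few compounds, and the source may have more. Where it says the series, first, only, none or still open, it means among the compounds named here.

Three compounds share one core and differ only in the group carried on one aromatic carbon. In a functional assay for antagonist activity at metabotropic glutamate receptor 5 (Rattus norvegicus) (on this read-out lower numbers stand for stronger inhibition and higher numbers for weaker inhibition), compound 1 `N#Cc1ccccc1-c1cc(F)cc(-n2nnc(-c3ccccn3)n2)c1` gives 6 nM, compound 2 `Nc1ccccc1-c1cc(F)cc(-n2nnc(-c3ccccn3)n2)c1` gives 8 nM, and compound 3 `Cc1ccncc1-c1cc(F)cc(-n2nnc(-c3ccccn3)n2)c1` gives 5 nM. Compound 2 holds the highest of these three numbers, yet every step around it is small: a 1.3-fold higher number from compound 1 to compound 2 (0.12 log units; within the scatter) and a 1.6-fold lower number from compound 2 to compound 3 (0.20 log units; within the scatter) both stay within the scatter, as does a 1.2-fold lower number from compound 1 to compound 3 (0.08 log units; within the scatter). Compound 4 `Cc1cncc(-c2cc(F)cc(-n3nnc(-c4ccccn4)n3)c2)c1` is not yet measured; it differs from compound 2 by 5-methylpyridin-3-yl in place of 2-aminophenyl on an aromatic carbon. The closest guide is the swap of 2-aminophenyl for 4-methylpyridin-3-yl, which stayed within the scatter, so the estimated step of a 1.3-fold lower number from compound 2 to compound 4 (0.12 log units; within the scatter) is expected to be small. Compound 4 is therefore expected to give about 6 nM, within a range of 3 nM to 13 nM.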

Compound 4, half-maximal inhibitory concentration: 499 nM
Compound 4: the middle estimate sits 83-fold (1.92 log units) below what was measured, outside the stated range (above it).
By their numbers in this assay, from the lowest: compounds 3, 1 and 2 (each within the scatter of the next); then compound 4.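

In this assay, going by these compounds alone, this position proves far less forgiving than the earlier compounds suggested: exchanging 4-methylpyridin-3-yl for 5-methylpyridin-3-yl, groups that differ only in where the methyl sits, gives a 100-fold higher number from compound 3 to compound 4 (2.00 log units; beyond the scatter) and shows that this placement matters greatly. The other comparisons agree, with a 62-fold higher number from compound 2 to compound 4 (1.80 log units; beyond the scatter) and an 83-fold higher number from compound 1 to compound 4 (1.92 log units; beyond the scatter) for the same entering group, so the close values of the first three compounds did not mean that any aromatic group would do. Nothing available explains this loss. On these data alone, whether plain pyridin-3-yl, without a methyl, would behave like compound 3 or like compound 4 remains open.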